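Pyrimidin-5-yl in Place of Pyridin-4-yl: Microsomal Stability

This account rests on a few compounds, and the source may have more. Where it says the series, first, only, none or still open, it means among the compounds named here.

Compound 1, `COc1cccc(S(=O)(=O)/C=C/c2ccncc2)c1`: 72%
Compound 2, `COc1ccc(S(=O)(=O)/C=C/c2ccncc2)cc1`: "not determined" (no result reported)
Compound 3, `COc1cccc(S(=O)(=O)/C=C/c2cncnc2)c1`: 96%

In an ADME assay on microsomes from liver (Homo sapiens) for metabolic stability, read by LC-MS, using NADPH, with stated times of 5 min and 30 min, tested at 1 uM (a lower number here means that less of the compound is left, a higher number that more of the compound is left), compound 1 gives 72%, while compound 3 gives 96%. The change between them is pyrimidin-5-yl in place of pyridin-4-yl on a double-bonded chain carbon bound to a double-bonded chain carbon, and it brought a number 24 percentage points higher from compound 1 to compound 3 (beyond the scatter). Compound 2 has "not determined" (no result reported) in this assay, so no number is known for it. The difference between the cores of compound 1 and compound 2 is not broken down here. Compound 4, `COc1ccc(S(=O)(=O)/C=C/c2cncnc2)cc1`, stands to compound 2 as compound 3 stands to compound 1: the same change, (pyrimidin-5-yl in place of pyridin-4-yl on a double-bonded chain carbon bound to a double-bonded chain carbon), at the same place. Because compound 3 already gives 96% and because the step from compound 1 to compound 3 was a number 24 percentage points higher from compound 1 to compound 3 (beyond the scatter), compound 4 is expected to retain a comparably large share. Compound 4 is estimated at 88% in this assay, with a range from 68% to 100%.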

Compound 4, percent of the compound remaining: 94%
Compound 4: the middle estimate sits 6 percentage points below what was measured; measured number inside the range.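

Compound 2 has no number to set against compound 4, so the step between them cannot be read. The compounds shown leave open what underlies the step from compound 1 to compound 3, and no measurement given here bears on it.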